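A few compounds are considered here, and "the series" means these few. Any claim that something is new, unique, unknown or untested is made for them only; others in the source may bear on it.

Measured in a functional assay on the whole organism for positive allosteric modulation, with Rattus norvegicus as the target; a higher number here means that more compound is needed for the effect, a lower number that less compound is needed:

Compound 1 `Cc1nn(C)c2c1C(c1cccc(Cl)c1)=NC(C)CN2`: 0.63 mg/kg
Compound 2 `Cc1nn(C)c2c1C(c1cccc(Cl)c1)=NC(C)(C)CN2`: 2.5 mg/kg

Of these two numbers compound 2 holds the higher one, so more of it is needed for the effect. Among the measured compounds shown here, the only measured step, a 4.0-fold higher number from compound 1 to compound 2 (0.60 log units; beyond the scatter), comes from a methyl in place of hydrogen on a saturated ring carbon of the shared core. Compound 3 `Cc1cccc(C2=NC(C)(C)CNc3c2c(C)nn3C)c1` keeps that methyl and differs from compound 2 elsewhere: methyl in place of chloro on an aromatic carbon. For the measured compounds named here, no measured step touches this part of the structure, so nothing among the measured pairs bears on the change; the one step known concerns a different place altogether. The expectation for compound 3 therefore rests on compound 2 alone, with no step beyond the scatter, as no change at the digits printed from compound 2 to compound 3 (within the scatter), and with a wide range. Compound 3 is estimated at 2.5 mg/kg, between 0.8 mg/kg and 8 mg/kg.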

Compound 3, minimum effective dose: > 10 mg/kg
Compound 3 was reported as a limit (the forecaster's own chance of this, stated with the estimate: 10%); middle value at least 4.0-fold (0.60 log units) from the limit.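

In this assay, the aromatic ring proves to be a second place where a small exchange counts: methyl in place of chloro gives an at least 4.0-fold higher number from compound 2 to compound 3 (0.60 log units; beyond the scatter). Among the compounds shown here, until now, the only measured change sat on a saturated ring carbon, and this step shows that swapping a single heavy atom on the 3-chlorophenyl group also raises the dose needed. Compound 3 is reported as a limit of the assay, not as a number: the limit of > 10 mg/kg in this assay, at which 1 of the 3 values shown sits.

Among the compounds shown, only chloro and methyl occupy this place, which leaves open how hydrogen, fluoro, methoxy or a nitrile there would compare. On these data alone, it also remains open whether the change from 3-chlorophenyl to 3-methylphenyl would give a similar step on compound 1, which has hydrogen in place of the extra methyl on the saturated ring carbon.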